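The source may report more compounds than this note shows. Statements on the series, on what has been measured and on what is new or still open speak of the compounds shown alone.

Compound 3 `CC1=NN(c2ccc(Cl)cc2)C(=O)C12C=CC(=O)C=C2c1ccc(C)cc1` gives the lowest of the two plain numbers in a functional assay on MDA-MB-231 cells (Homo sapiens) for antiproliferative activity, read by CCK-8 assay, with a stated time of 72 h (on this read-out higher numbers stand for weaker inhibition and lower numbers for stronger inhibition), namely 14300 nM, with compound 1 `CC1=NN(c2cccc(Cl)c2)C(=O)C12C=CC(=O)C=C2c1ccccc1` nearest at 30100 nM. Compound 2 `CC1=NN(c2ccc(Cl)cc2)C(=O)C12C=CC(=O)C=C2c1ccccc1` reaches only a limit of this assay, > 100000 nM. Compound 4 `CC1=NN(c2cccc(Cl)c2)C(=O)C12C=CC(=O)C=C2c1ccc(C)cc1` differs from compound 3 by 3-chlorophenyl in place of 4-chlorophenyl on an amide-type nitrogen in a ring. Among the measured compounds shown here, two measured steps bear on this change: an at least 3.3-fold higher number from compound 1 to compound 2 (0.52 log units; beyond the scatter), which is the reverse of the present change, and an at least 6.9-fold lower number from compound 2 to compound 3 (0.84 log units; beyond the scatter); both rest on a limit (the limit of > 100000 nM in this assay, at which 1 of the 3 values shown sits), so only their smallest sizes are known. Reversing the first step is therefore expected to lower the number for compound 4 by at least a modest margin, a 2.9-fold lower number from compound 3 to compound 4 (0.46 log units; beyond the scatter). Compound 4 is accordingly estimated at 5000 nM in this assay, within a range of 1800 nM to 14000 nM.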

Compound 4, half-maximal inhibitory concentration: 3820 nM
The estimate for compound 4 lay 1.3-fold (0.12 log units) above the measured number, and the stated range covers the measured number.
By their numbers in this assay, from the lowest: compound 4; then compound 3; then compound 1. At a limit, above all of these: compound 2.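

In this assay, the swap of 4-chlorophenyl for 3-chlorophenyl on the amide-type nitrogen in a ring now has a full size, a 3.7-fold lower number from compound 3 to compound 4 (0.57 log units; beyond the scatter), and methyl in place of hydrogen on an aromatic carbon also has one, a 7.9-fold lower number from compound 1 to compound 4 (0.90 log units; beyond the scatter). The chlorine shift recurs with the methyl present: the same change on two cores in this assay, an at least 3.3-fold higher number (0.52 log units; beyond the scatter) from compound 1 to compound 2 and a 3.7-fold higher number (0.57 log units; beyond the scatter) from compound 4 to compound 3; the limit leaves it open whether they differ The methyl gain likewise recurs with either chlorophenyl: the same change on two cores in this assay, an at least 6.9-fold lower number (0.84 log units; beyond the scatter) from compound 2 to compound 3 and a 7.9-fold lower number (0.90 log units; beyond the scatter) from compound 1 to compound 4; the limit leaves it open whether they differ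

The compounds shown leave open whether 3-bromophenyl or 3-methoxyphenyl on that nitrogen would lower the number further. They also leave open how an ethyl group or an amine would compare with the methyl on that aromatic carbon.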